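From trifluoromethyl to chloro: how large a step?

This account rests on a few compounds, and the source may have more. Where it says the series, first, only, none or still open, it means among the compounds named here.

Compound 1 `Cc1cccc(-c2nc3c(c(C)nn3-c3ccccc3)c(-c3ccccc3O)c2C#N)c1`: 42000 nM
Compound 2 `Cc1nn(-c2ccccc2)c2nc(-c3ccc(C(F)(F)F)cc3)c(C#N)c(-c3ccccc3O)c12`: 3500 nM

Among the measured compounds shown here, in a physicochemical assay for solubility, read by spectrophotometry, in phosphate buffer, with a stated time of 18 h, at pH 7.4 (on this read-out lower numbers stand for lower solubility and higher numbers for higher solubility), compound 2 gives 3500 nM, the lower of the two numbers so far. Compound 3 `Cc1nn(-c2ccccc2)c2nc(-c3ccc(Cl)cc3)c(C#N)c(-c3ccccc3O)c12` has not yet been measured. It differs from compound 2 in one group, with chloro in place of trifluoromethyl on an aromatic carbon. For the measured compounds named here, only one measured step bears on this change: a 12-fold lower number from compound 1 to compound 2 (1.08 log units; beyond the scatter). That step was large, but it replaced 3-methylphenyl with 4-(trifluoromethyl)phenyl. Going by the values given here, the change here is narrower, from 4-(trifluoromethyl)phenyl to 4-chlorophenyl, and no measured pair shows this swap directly. A much smaller move is therefore expected, probably within the scatter and leaning slightly upward. The estimated change is a 1.4-fold higher number from compound 2 to compound 3 (0.15 log units; within the scatter). For compound 3, the estimate is 5000 nM, with an expected range from 1800 nM to 14000 nM.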

Compound 3, solubility: 3800 nM
The estimate for compound 3 lay 1.3-fold (0.12 log units) above the measured number; measured number inside the range.
By their numbers in this assay, from the lowest: compounds 2 and 3 (each within the scatter of the next); then compound 1.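

In this assay, putting chloro in place of trifluoromethyl on this aromatic carbon, para to a large group, gives a 1.1-fold higher number from compound 2 to compound 3 (0.04 log units; within the scatter), so a single chlorine atom and a group of 4 heavy atoms cannot be told apart here. Replacing 3-methylphenyl with 4-chlorophenyl gives an 11-fold lower number from compound 1 to compound 3 (1.04 log units; beyond the scatter), a large step like a 12-fold lower number from compound 1 to compound 2 (1.08 log units; beyond the scatter), so this large step is not tied to trifluoromethyl alone. Nothing measured here gives a reason for either step.

The compounds shown leave open whether the large step follows from the change of group or from where the group sits, which a 4-methylphenyl group could help separate. They also leave open whether an amine or a carboxylic acid at this same place would give a number near those of compound 2 and compound 3.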